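A few compounds are considered here, and "the series" means these few. Any claim that something is new, unique, unknown or untested is made for them only; others in the source may bear on it.

For the measured compounds named here, compound 3 `Cc1ccc(OCC(=O)N2CCN(c3ccc(C(F)(F)F)cc3[C@@H](N)CC(C)C)CC2)cc1` stands at the top of the numbers measured so far in an assay on HEK293 cells for displacement of a labelled ligand from Melanocortin receptor 4 (Homo sapiens); a lower number here means a stronger inhibitor, a higher number a weaker inhibitor: in that assay compound 3 gives 4400 nM. Its nearest neighbour is compound 1 `CC(C)C[C@H](N)c1cc(C(F)(F)F)ccc1N1CCN(C(=O)COc2ccc3ccccc3c2)CC1`, which in this assay gives 2000 nM; the two differ only in the group on the oxygen on a saturated carbon, and the step of a 2.2-fold higher number from compound 1 to compound 3 (0.34 log units; beyond the scatter) is modest. Compound 2 `CC(C)C[C@H](N)c1ccccc1N1CCN(C(=O)[C@H](C)Cc2ccc(Cl)cc2F)CC1`, built on a core without the trifluoromethyl group and carrying a different acyl group, gives 67 nM in this assay and is the furthest from compound 3. Compound 4 `CC(C)C[C@H](N)c1cc(C(F)(F)F)ccc1N1CCN(C(=O)CCC(=O)N(C)C)CC1` differs from compound 3 in that ((dimethylcarbamoyl)methyl in place of 4-methylphenoxy on a saturated chain carbon bound to a carbonyl carbon). Going by the values given here, no measured step bears directly on this replacement: the one measured step exchanges one aromatic ring for another, and compound 2 differs from compound 3 in more than one place. The expectation therefore rests on little. Compound 4 is expected to give a somewhat higher number, a step estimated at a 1.4-fold higher number from compound 3 to compound 4 (0.13 log units; within the scatter). For compound 4 the estimate in this assay is 6000 nM, within a range from 1500 nM to 25000 nM.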

Compound 4, inhibition constant: > 10000 nM
Compound 4 ended at the assay's limit (the forecaster's own chance of this, stated with the estimate: 30%); middle value at least 1.6-fold (0.22 log units) away from the limit.
By their numbers in this assay, from the lowest: compound 2; then compound 1; then compound 3. At a limit, above all of these: compound 4.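

In this assay compound 4 gives > 10000 nM, which is a limit of the assay and not a number: the limit of > 10000 nM in this assay, at which 1 of the 4 values shown sits.

At this place, on a saturated chain carbon bound to a carbonyl carbon, (dimethylcarbamoyl)methyl in place of 4-methylphenoxy gives an at least 2.2-fold higher number from compound 3 to compound 4 (0.35 log units; beyond the scatter), and in place of (naphthalen-2-yl)oxy it gives an at least 5.0-fold higher number from compound 1 to compound 4 (0.69 log units; beyond the scatter). The earlier step only exchanged one aromatic ring for another, whereas this change removes the ring and the ether oxygen, and among these three compounds only the one without a ring reaches the limit.

Going by these compounds, how far compound 4 lies past the limit stays open, so both steps give only a smallest size. Also open, on these data alone, is whether the ring, the ether oxygen or the dimethylamide decides the result, which a phenyl group on the same chain, or an amine or a carboxylic acid at the end of it, could begin to separate.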